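Swapping an Aryl Amide for a Branched Alkyl Amide

This account rests on a few compounds, and the source may have more. Where it says the series, first, only, none or still open, it means among the compounds named here.

Compound 1, `O=C(Nc1ccccc1)c1cccc2[nH]c(-c3ccccn3)nc12`, gives 17.9 uM in an ADME assay on Vero cells (Chlorocebus sabaeus) for cytotoxicity; a higher number here means that more compound is tolerated, a lower number that less compound is tolerated.
Compound 2, `Cc1csc(NC(=O)c2cccc3[nH]c(-c4ccncc4)nc23)n1`, gives 111 uM in this assay.
Compound 3, `COc1ccc(-c2nc3c(C(=O)Nc4ccccc4F)cccc3[nH]2)cc1OC`, gives 24.5 uM in this assay.

All three share the same core and differ in the group on the amide-type nitrogen and in the aromatic ring attached to the core. On these numbers, compound 3 holds the second highest value of the three. Its nearest neighbour is compound 1, whose value lies within the usual scatter of that of compound 3, so the two cannot be told apart. Compound 2 stands furthest away, with a value higher than that of compound 3 by a margin beyond the scatter.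

Compound 4, `CCC(CC)NC(=O)c1cccc2[nH]c(-c3ccc(OC)c(OC)c3)nc12`, has not yet been measured. It differs from compound 3 in one place: pentan-3-yl in place of 2-fluorophenyl on an amide-type nitrogen. Within the data shown here, no pair of measured compounds shows this kind of exchange, so there is no measured step to lean on. With that in mind, the expected step in this assay is small and in no sure direction. The estimate for compound 4 is 30 uM, within the range 12 uM to 75 uM. The step this estimate implies, a 1.2-fold higher number from compound 3 to compound 4 (0.09 log units; within the scatter), is expected to lie within the scatter.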

Compound 4, half-maximal toxic concentration: 2.23 uM
The estimate for compound 4 lay 13-fold (1.13 log units) above the measured number, outside the stated range (below it).
By their numbers in this assay, from the lowest: compound 4; then compounds 1 and 3 (each within the scatter of the next); then compound 2.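

In this assay, putting pentan-3-yl in place of 2-fluorophenyl on the amide-type nitrogen gives an 11-fold lower number from compound 3 to compound 4 (1.04 log units; beyond the scatter) and means that far less compound is tolerated. Among these compounds, this is the first step in the set that changes only this one place, since the earlier compounds differ in both the amide group and the aromatic ring attached to the core, and it shows that the group on this nitrogen can by itself move the toxic concentration by more than the usual scatter. Nothing available here accounts for the size or direction of this step.

Among the compounds shown here, the single step cannot separate losing the aromatic ring from gaining a branched chain, and a cyclohexyl group or a straight pentyl chain on the same nitrogen would help tell these two changes apart. On these data alone, it also remains open whether the same exchange would give a similar step with a different aromatic ring on the core, such as the pyridine-type rings of compound 1 and compound 2.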